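Cyclopropyl for methoxyphenyl on the lactam nitrogen

The source may report more compounds than this note shows. Statements on the series, on what has been measured and on what is new or still open speak of the compounds shown alone.

The shared core is seen in compound 1 `COc1cccc(N2C(=O)COc3ccc(-c4cnc(Cl)c(NS(=O)(=O)c5ccc(F)cc5)c4)cc32)c1`, compound 2 `COc1ccc(N2C(=O)COc3ccc(-c4cnc(OC)c(NS(=O)(=O)c5ccc(F)cc5)c4)cc32)cc1` and compound 3 `O=C1COc2ccc(-c3ccc(O)cc3)cc2N1`. In a functional assay on A549 cells (Homo sapiens) for antiproliferative activity, read by MTT assay, with a stated time of 72 h (a lower number here means a stronger inhibitor, a higher number a weaker inhibitor), compound 1 gives 32700 nM, the higher of the two numbers reported, while compound 2 gives 1350 nM, a gap that lies beyond the scatter. For compound 3 this assay reports only a limit, > 40000 nM, a line described as the limit of > 40000 nM in this assay, at which 1 of the 3 values shown sits.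

The untested compound 4 `O=C1COc2ccc(-c3cnc(Cl)c(NS(=O)(=O)c4ccc(F)cc4)c3)cc2N1C1CC1` differs from compound 1 in one place: cyclopropyl in place of 3-methoxyphenyl on an amide-type nitrogen in a ring. Going by the values given here, no measured pair shows this change, so its size is unknown. The chloro-substituted compound 1 already sits at a weak level, and the smaller cyclopropyl group is not expected to shift the number far; a step either within the scatter or a modest loss is anticipated. Compound 4 is estimated at 30000 nM, with a range from 9000 nM to 90000 nM. The expected step is a 1.1-fold lower number from compound 1 to compound 4 (0.04 log units; within the scatter).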

Compound 4, half-maximal inhibitory concentration: 4330 nM
Estimate against measurement, compound 4: 6.9-fold (0.84 log units) above, and the stated range ends above it.
By their numbers in this assay, from the lowest: compound 2; then compound 4; then compound 1. At a limit, above all of these: compound 3.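

In this assay, cyclopropyl in place of 3-methoxyphenyl on the amide-type nitrogen in a ring gives a 7.6-fold lower number from compound 1 to compound 4 (0.88 log units; beyond the scatter), the first step measured at this position. The position therefore responds to the group it carries, and in this pair the 3-methoxyphenyl group is not required for antiproliferative activity, since the smaller cyclopropyl gives the lower number. Nothing in the data shown accounts for the size of this step.

A single pair cannot show whether the lower number follows from losing the six-membered aromatic ring, from losing the methoxy group, or from gaining cyclopropyl itself. It also leaves open how a methyl group, a longer alkyl chain or an aminoethyl chain on the same nitrogen would compare.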